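The compounds below may be only part of what the source reports. "The series", "measured", "known", "first", "only" and "open" are said of these compounds alone.

In an ADME assay on Vero cells (Chlorocebus sabaeus) for cytotoxicity, read by resazurin assay, with a stated time of 72 h (a higher number here means a weaker inhibitor, a lower number a stronger inhibitor), compound 1 (`O=C(CCN1CCN(c2ccc(F)cc2)CC1)c1ccccc1`) gives 13400 nM as the lowest of three numbers. Compound 2 (`O=C(CCN1CCN(c2ccc(F)cc2)CC1)c1ccc(F)c(Br)c1`) gives 352000 nM and compound 3 (`O=C(CCN1CCN(c2ccc(F)cc2)CC1)c1ccc(F)c(Cl)c1`) gives 185000 nM with the two inside the scatter of each other (a 1.9-fold lower number from compound 2 to compound 3 (0.28 log units; within the scatter)). Compound 4 (`O=C(CCN1CCN(c2ccc(F)cc2)CC1)c1ccc(OC(F)(F)F)cc1`) carries trifluoromethoxy in place of hydrogen on an aromatic carbon, para to a large group (trifluoromethoxy in place of hydrogen on an aromatic carbon). Among the measured compounds shown here, two measured steps bear on this change, both large and both made on the same phenyl: a 26-fold higher number from compound 1 to compound 2 (1.42 log units; beyond the scatter) and a 14-fold higher number from compound 1 to compound 3 (1.14 log units; beyond the scatter). Neither brings in trifluoromethoxy, so they are only a loose guide. A smaller rise in this assay is therefore expected (a 4.5-fold higher number from compound 1 to compound 4 (0.65 log units; beyond the scatter)). Compound 4 is estimated at 60000 nM with an expected range from 15000 nM to 250000 nM.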

Compound 4, half-maximal inhibitory concentration: 70300 nM
Beside the measured number, compound 4's estimate is 1.2-fold (0.07 log units) below it, and the stated range covers the measured number.
By their numbers in this assay, from the lowest: compound 1; then compound 4; then compounds 3 and 2 (each within the scatter of the next).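

Trifluoromethoxy para to a large group is the first single replacement of hydrogen on this phenyl, and a 5.2-fold higher number from compound 1 to compound 4 (0.72 log units; beyond the scatter) shows that this one group is enough to raise the number. The earlier steps shown here each brought in two halogens together, so they could not show the effect of one group at this place. No measurement at hand accounts for the rise.

As far as these compounds go, whether the rise belongs to trifluoromethoxy itself or to any group at this place stays open. A methoxy or an amine on the same carbon would separate the two readings.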